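Methyl in Place of Chloro on a Shared Core

A few compounds are considered here, and "the series" means these few. Any claim that something is new, unique, unknown or untested is made for them only; others in the source may bear on it.

Compound 1 `Cc1nc(-c2cccnc2)sc1-c1nnc(Cc2ccccc2)o1`, compound 2 `COc1ccccc1-c1nnc(-c2sc(-c3cccnc3)nc2C)o1` and compound 3 `Cc1nc(-c2cccnc2)sc1-c1nnc(-c2ccc(Cl)cc2)o1` share one core and differ only in the group carried on one aromatic carbon. In an ADME assay on PANC-1 cells (Homo sapiens) for cytotoxicity, read by MTT assay (on this read-out higher numbers stand for lower toxicity in this test and lower numbers for higher toxicity in this test), compound 1 gives > 100 ug/mL, which is a limit of the test and not a number. Compound 2 gives > 100 ug/mL, again a limit. Compound 3 gives > 100 ug/mL, also a limit. The steps a step that the two limits leave unreadable from compound 1 to compound 2, a step that the two limits leave unreadable from compound 1 to compound 3 and a step that the two limits leave unreadable from compound 2 to compound 3 therefore cannot be sized, since all three values share (the limit of > 100 ug/mL in this assay, at which 3 of the 3 values shown sit). Compound 4 `Cc1ccc(-c2nnc(-c3sc(-c4cccnc4)nc3C)o2)cc1` differs from compound 3 by methyl in place of chloro on an aromatic carbon. The measured steps bear on this change only in showing no value below the limit, so no readable step in this assay is expected. Compound 4 is expected to give 150 ug/mL, between 80 ug/mL and 300 ug/mL. The step that the limit leaves unreadable from compound 3 to compound 4 is thus expected to stay within the scatter.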

Compound 4, half-maximal cytotoxic concentration: > 100 ug/mL
Compound 4 ended at the assay's limit; the forecaster's own chance of this, stated with the estimate: 85%; the middle value lies beyond the limit too.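

Compound 4 sits at the same limit as compound 1, compound 2 and compound 3, so no step among these compounds can be read: the limit of > 100 ug/mL in this assay, at which 4 of the 4 values shown sit.

The compounds shown leave open whether any group at this place on the shared core would give a readable value in this assay at all.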